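The compounds below may be only part of what the source reports. "The series", "measured", "known", "first", "only" and "open" are said of these compounds alone.

Compound 3 `Cc1ccnc(-c2cnc(C(=O)CCCCCCc3ccccc3)o2)c1` gives 0.6 nM in an assay (Rattus norvegicus) for inhibition of Fatty-acid amide hydrolase 1 (Homo sapiens) (on this read-out lower numbers stand for stronger inhibition and higher numbers for weaker inhibition), the lowest number among the three measured compounds. Compound 1 `O=C(CCCCCCc1ccccc1)c1ncc(-c2cccc(O)c2)o1` gives 50 nM, and compound 2 `COc1ccc(-c2cnc(C(=O)CCCCCCc3ccccc3)o2)cc1` gives 100 nM. The step is a 2.0-fold higher number from compound 1 to compound 2 (0.30 log units; within the scatter). Against these two, the steps are an 83-fold lower number from compound 1 to compound 3 (1.92 log units; beyond the scatter) and a 170-fold lower number from compound 2 to compound 3 (2.22 log units; beyond the scatter), both large.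

Compound 4 `Cc1cccc(-c2cnc(C(=O)CCCCCCc3ccccc3)o2)n1` differs from compound 3 in one place: 6-methylpyridin-2-yl in place of 4-methylpyridin-2-yl on an aromatic carbon. The pyridinyl ring that set compound 3 apart from compounds 1 and 2 is kept; only the position of the methyl on that ring moves. Among the measured compounds shown here, none of the measured steps compares two methylpyridinyl groups, so nothing measured speaks directly to this change. The large gains seen in the steps to compound 3 came with the switch from a phenyl-type ring to the pyridinyl ring, not from the methyl position. The expectation is therefore a step near or within the scatter, with the direction uncertain, as a 2.0-fold higher number from compound 3 to compound 4 (0.30 log units; within the scatter). Compound 4 is expected to give about 1.2 nM in this assay, within a range from 0.3 nM to 6 nM.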

Compound 4, inhibition constant: 3.3 nM
Beside the measured number, compound 4's estimate is 2.8-fold (0.44 log units) below it; low and high end bracket the measured number.
By their numbers in this assay, from the lowest: compound 3; then compound 4; then compounds 1 and 2 (each within the scatter of the next).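

In this assay, the place of the methyl on the pyridinyl ring matters: with the same atoms joined differently, 6-methylpyridin-2-yl in place of 4-methylpyridin-2-yl gives a 5.5-fold higher number from compound 3 to compound 4 (0.74 log units; beyond the scatter), so the two groups are not interchangeable at this position. Much of the advantage over the phenyl-type rings still remains with the methyl in its new place, with a 30-fold lower number from compound 2 to compound 4 (1.48 log units; beyond the scatter) and a 15-fold lower number from compound 1 to compound 4 (1.18 log units; beyond the scatter), and so in these compounds it does not depend on the 4-methylpyridin-2-yl group alone. Nothing available accounts for the difference between the two methyl positions.

On these data alone, it remains open how plain pyridin-2-yl, carrying no methyl, would compare with these two groups. Also open, as far as these compounds go, is how 5-methylpyridin-2-yl or 6-ethylpyridin-2-yl would fare at this same position.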